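Permeability of a Methoxyphenoxy Variant of Compound 3

The source may report more compounds than this note shows. Statements on the series, on what has been measured and on what is new or still open speak of the compounds shown alone.

Compound 3 `COc1cccc(CNCCCNc2ccnc3cc(-c4ccc(C(C)(C)C)cc4)ccc23)c1O` gives 237 10^-6 cm/s in an ADME assay for permeability, using PAMPA, with a stated time of 30 min, at pH 7.4; on this read-out higher numbers stand for higher permeability and lower numbers for lower permeability. That places it second highest of the three measured compounds. Compound 1 `COc1cccc(Oc2ccc3c(NCCCNCc4cccc(OC)c4O)ccnc3c2)c1` gives 317 10^-6 cm/s, and the step of a 1.3-fold lower number from compound 1 to compound 3 (0.13 log units; within the scatter) lies within the usual scatter, so the two cannot be told apart on this read-out. Compound 2 `COc1cccc(CNCCCNc2ccnc3cc(Cc4cccc(C(F)(F)F)c4)ccc23)c1O` gives 23 10^-6 cm/s, and the step of a 10-fold higher number from compound 2 to compound 3 (1.01 log units; beyond the scatter) is clearly beyond the scatter.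

Compound 4 `COc1ccccc1Oc1ccc2c(NCCCNCc3cccc(OC)c3O)ccnc2c1` differs from compound 3 in one place: 2-methoxyphenoxy in place of 4-(tert-butyl)phenyl on an aromatic carbon. The measured step that bears most on this change is a 1.3-fold lower number from compound 1 to compound 3 (0.13 log units; within the scatter), which shows that trading a 3-methoxyphenoxy group for a 4-(tert-butyl)phenyl group made no difference that rises above the scatter. Going back from the 4-(tert-butyl)phenyl group to a methoxyphenoxy group, here the 2-methoxyphenoxy, is therefore expected to leave the number about where it is, so the expected step of a 1.2-fold higher number from compound 3 to compound 4 (0.09 log units; within the scatter) should stay within the scatter. Compound 4 is estimated at 290 10^-6 cm/s in this assay, with a range from 150 10^-6 cm/s to 500 10^-6 cm/s.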

Compound 4, apparent permeability in the ADME assay: 317 10^-6 cm/s
The estimate for compound 4 lay 1.1-fold (0.04 log units) below the measured number; the range from low to high includes it.
By their numbers in the ADME assay, from the lowest: compound 2; then compounds 3, 1 and 4 (each within the scatter of the next).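

In the ADME assay, the step of no change at the digits printed from compound 1 to compound 4 (within the scatter) shows that the 2-methoxyphenyl and 3-methoxyphenyl groups on the oxygen cannot be told apart, and the step of a 1.3-fold higher number from compound 3 to compound 4 (0.13 log units; within the scatter) puts 2-methoxyphenoxy level with 4-(tert-butyl)phenyl, while the step of a 14-fold higher number from compound 2 to compound 4 (1.14 log units; beyond the scatter) leaves compound 2 alone at the low end. In a physicochemical assay for solubility, with a stated time of 18 h, at pH 7.4 (on this read-out lower numbers stand for lower solubility and higher numbers for higher solubility), compound 3 gives 32000 nM and compound 4 gives 14500 nM. So a change that moves nothing beyond the scatter in the ADME assay does cost solubility: the measured solubility of compound 3, 32000 nM, and of compound 4, 14500 nM, a 2.2-fold lower number (0.34 log units; beyond the scatter)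

The compounds shown leave open how a plain phenoxy group, or a phenoxy group carrying an amine or a carboxylic acid, would behave in either assay. They also cannot separate the part played by the oxygen link from that of the methoxy group, for the two arrive together in this one change.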